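A few compounds are considered here, and "the series" means these few. Any claim that something is new, unique, unknown or untested is made for them only; others in the source may bear on it.

Measured so far:
compound 1, `COc1ccc(NC(=O)COC(=O)/C=C/c2cc(OC)c(OCc3ccccc3)c(OC)c2)cc1`: in a functional assay on BEL-7404 cells (Homo sapiens) for cytotoxicity, read by MTT assay, with a stated time of 72 h (on this read-out lower numbers stand for stronger inhibition and higher numbers for weaker inhibition), compound 1 gives > 200000 nM, a limit of the assay.
compound 2, `COc1ccc(/C=C/C(=O)OCC(=O)Nc2ccccc2)cc1OC`: in this assay compound 2 gives > 200000 nM, likewise a limit.

Compound 2 therefore stands exactly where every value shown stands, namely at the limit of > 200000 nM in this assay, at which 2 of the 2 values shown sit. Among the compounds with values here, no step between measured compounds exists, so the move to compound 3, `COc1ccc(/C=C/C(=O)OCC(=O)Nc2ccc(Cl)cc2)cc1OC`, rests on the structural change alone: chloro in place of hydrogen on an aromatic carbon. From a limit no direction can be read, and the step expected in this assay is a number no higher from compound 2 to compound 3 (the limit leaves the size open), none beyond the scatter. Compound 3 is estimated at 200000 nM, within 80000 nM to 500000 nM, most probably reported again only as a limit.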

Compound 3, half-maximal inhibitory concentration: 120000 nM
Beside the measured number, compound 3's estimate is 1.7-fold (0.22 log units) above it; the measured number falls inside the stated range.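

Chloro in place of hydrogen on an aromatic carbon, para to a large group, gives the only number among the compounds shown in this assay that is not a limit. The step is an at least 1.6-fold lower number from compound 2 to compound 3 (0.22 log units; that floor lies within the scatter). Only a floor can be read because compound 2 stands at a limit: the limit of > 200000 nM in this assay, at which 2 of the 3 values shown sit.

Open, as far as these compounds go, is what a bromo, a methyl or an amine in place of this chloro would give in this assay. Also open, from the compounds shown here alone, is whether chloro elsewhere on the same ring would give a similar number.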